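The source may hold more compounds than are shown below. What is called first, only, known or untested is meant among the compounds shown, and "the series" means these compounds.

Of the compounds shown here, three have so far been tested in an ADME assay on RAW264.7 cells (Mus musculus) for cytotoxicity, read by MTT assay, with a stated time of 48 h; on this read-out lower numbers stand for higher toxicity in this test and higher numbers for lower toxicity in this test. Compound 1 `CC(=O)OC[C@H]1O[C@H](OC[C@@H](Cn2cc(CN(c3nc(-c4ccccc4)no3)C3CCCCC3)nn2)OC(C)=O)C=C[C@@H]1OC(C)=O` gives 28.6 ug/mL, which places it at the low end of the three numbers, but its gap to compound 3 `CCCCCCCCCCc1cn(C[C@@H](CO[C@@H]2C=C[C@H](OC(C)=O)[C@@H](COC(C)=O)O2)OC(C)=O)nn1` with 30.4 ug/mL and to compound 2 `C#CCN(c1nc(-c2cccc([N+](=O)[O-])c2)no1)C1CCCCC1` with 34.2 ug/mL lies within the scatter, so the three cannot be told apart. Compound 4 `CC(=O)OC[C@H]1O[C@H](OC[C@@H](Cn2cc(CN(c3nc(-c4cccc([N+](=O)[O-])c4)no3)C3CCCCC3)nn2)OC(C)=O)C=C[C@@H]1OC(C)=O` has not yet been measured. It differs from compound 1 in one place: nitro in place of hydrogen on an aromatic carbon. Compound 2 already carries a nitro group on the same kind of ring and gives 34.2 ug/mL, a number close to that of compound 1, so no change beyond the scatter is expected. The step of a 1.0-fold higher number from compound 1 to compound 4 (0.02 log units; within the scatter) is estimated to be essentially none. Compound 4 is expected to give 30 ug/mL, in a range from 18 ug/mL to 50 ug/mL.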

Compound 4, half-maximal cytotoxic concentration: 100 ug/mL
The estimate for compound 4 lay 3.3-fold (0.52 log units) below the measured number; the whole stated range lies below it.
By their numbers in this assay, from the lowest: compounds 1, 3 and 2 (each within the scatter of the next); then compound 4.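

In this assay, among the compounds shown here, replacing phenyl with 3-nitrophenyl gives a 3.5-fold higher number from compound 1 to compound 4 (0.54 log units; beyond the scatter) on the shared core, the first step here that lies beyond the scatter. This aromatic carbon is therefore not a silent place: a single nitro group moves the number towards lower toxicity in this test. Nothing measured here explains the rise. On these data alone, whether this step belongs to nitro alone remains open. A nitrile or an amine in the same place would show whether other groups there move the number as well.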